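The source may report more compounds than this note shows. Statements on the series, on what has been measured and on what is new or still open speak of the compounds shown alone.

The measured compounds and their values in an ADME assay on MT4 cells (Homo sapiens) for cytotoxicity, read by spectrophotometry, with a stated time of 5 days; on this read-out lower numbers stand for higher toxicity in this test and higher numbers for lower toxicity in this test:

compound 1, `CN(C)CN1C(=O)/C(=N\NC(=S)NO)c2cc(F)ccc21`: 599000 nM
compound 2, `CONC(=S)N/N=C1\C(=O)N(CN(C)C)c2ccc(C)cc21`: 622000 nM
compound 3, `CCn1cc(C(=O)O)c(=O)c2cc(F)c(N3CCN(CN4C(=O)/C(=N\NC(=S)NOC)c5cc(F)ccc54)CC3)cc21`: 144000 nM

Compound 1 stands second highest of the three numbers. Its nearest neighbour is compound 2, whose value lies within the scatter of repeated measurements, so the two cannot be told apart on this read-out. Compound 3 gives the lowest number of the set, and the gap between compound 3 and compound 1 lies beyond the scatter, so compound 3 is the more toxic of that pair in this assay.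

Compound 4, `CN(C)CN1C(=O)/C(=N\NC(=S)NO)c2cc(Cl)ccc21`, differs from compound 1 in one place: chloro in place of fluoro on an aromatic carbon. Among the compounds with values here, no measured pair in this set shows what a change of this kind does in this assay, so the expectation rests on compound 1 alone. The step from compound 1 to compound 4 is expected to be small, a 1.3-fold lower number from compound 1 to compound 4 (0.12 log units; within the scatter), and most likely within the scatter, leaning if anything toward a slightly lower number. Compound 4 is therefore estimated at 450000 nM, with a range from 200000 nM to 1000000 nM.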

Compound 4, half-maximal cytotoxic concentration: 610000 nM
For compound 4 the middle estimate is 1.4-fold (0.13 log units) below the measured one; the measured number falls inside the stated range.
By their numbers in this assay, from the lowest: compound 3; then compounds 1, 4 and 2 (each within the scatter of the next).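

In this assay, chloro in place of fluoro on an aromatic carbon gives a 1.0-fold higher number from compound 1 to compound 4 (0.01 log units; within the scatter), so the two compounds cannot be told apart on this read-out. Within the data shown here, this is the first pair in the set that differs in one place, and it shows that at this place, meta to a fused ring and para to a fused ring, this change leaves no detectable mark on the number. Nothing in the available data speaks to why this is so.

Open, going by these compounds, is whether a group other than these two halogens at the same place, such as an amine, a nitrile or a carboxylic acid, would shift the number beyond the scatter. Also open, on these data alone, is whether chloro in place of fluoro would behave the same way on the larger compound 3.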